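From 3-chlorobenzyl to 2-bromobenzyl on a shared core

This account rests on a few compounds, and the source may have more. Where it says the series, first, only, none or still open, it means among the compounds named here.

In a functional assay on HCT-116 cells (Homo sapiens) for antiproliferative activity, read by MTT assay, with a stated time of 24 h (on this read-out higher numbers stand for weaker inhibition and lower numbers for stronger inhibition), compound 1 `COc1cccc(C(=O)Oc2ccc3c(=O)c(-c4cc(OC)c(OC)cc4OC)coc3c2)c1` reads > 10000 nM, which is a limit of the assay and not a number. Within the data shown here, compound 2 `COc1cc(OC)c(-c2coc3cc(OCc4cccc(Cl)c4)ccc3c2=O)cc1OC` gives 1330 nM, the only exact value so far. Compound 3 `COc1cc(OC)c(-c2coc3cc(OCc4ccccc4Br)ccc3c2=O)cc1OC` keeps the shared core of compound 2 and changes only the outer ring: 2-bromophenyl in place of 3-chlorophenyl on a saturated chain carbon bound to an oxygen on an aromatic ring. Just one measured step bears on this. Putting 3-chlorobenzyl in place of (3-methoxyphenyl)carbonyl produced an at least 7.5-fold lower number from compound 1 to compound 2 (0.87 log units; beyond the scatter). That step replaced a whole group, whereas here a benzyl group stays in place and only its halogen differs, so it offers a weak guide to size. Among the measured compounds shown here, no measured pair tests a change of this kind. The expected result is a 1.1-fold higher number from compound 2 to compound 3 (0.05 log units; within the scatter), with no shift beyond the scatter in either direction. For compound 3, the estimated value is 1500 nM, with an expected range from 500 nM to 4500 nM.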

Compound 3, half-maximal inhibitory concentration: 4550 nM
Estimate against measurement, compound 3: 3.0-fold (0.48 log units) below; the measured number lies above the stated range.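

In this assay, the step to 2-bromobenzyl gives a 3.4-fold higher number from compound 2 to compound 3 (0.53 log units; beyond the scatter), so this outer ring is sensitive: with the benzyl group kept and the heavy-atom count unchanged, swapping the halogen and where it sits is enough to move the reading beyond the scatter. The 2-bromobenzyl group still compares well with the (3-methoxyphenyl)carbonyl group, with an at least 2.1-fold lower number from compound 1 to compound 3 (0.34 log units; beyond the scatter). That comparison gives only a bound, as compound 1 reads > 10000 nM, a limit of the assay and not a number: the limit of > 10000 nM in this assay, at which 1 of the 3 values shown sits.

The halogen and its place on the ring change together in this step, so the compounds shown cannot separate the two. A 2-chlorobenzyl or 3-bromobenzyl group would change only one of them, while plain benzyl would show what the halogen contributes at all.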